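A few compounds are considered here, and "the series" means these few. Any claim that something is new, unique, unknown or untested is made for them only; others in the source may bear on it.

Working notes on the series.

Of the compounds shown here, three with the shared core have been measured in a functional assay on K562 cells (Homo sapiens) for cytotoxicity, read by WST assay, with a stated time of 72 h; a higher number here means a weaker inhibitor, a lower number a stronger inhibitor. Compound 1 `COc1cc2c(Nc3nc4ccc(C(=O)Nc5c(C)cccc5Cl)cc4s3)ncnc2cc1OCCCN1CCCC1` gives 13300 nM. Compound 2 `COc1cc2c(Nc3nc4ccc(C(=O)Nc5c(C)cccc5Cl)cc4s3)ncnc2cc1OCCCN1CCCCC1` gives 12500 nM. Compound 3 `COc1cc2c(Nc3nc4ccc(C(=O)Nc5c(C)cc(C)cc5C)cc4s3)ncnc2cc1OCCCN1CCCCC1` gives 9300 nM. The three numbers sit close together, and none of the steps among them reaches beyond the scatter.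

The change from compound 2 to compound 1 is pyrrolidin-1-yl in place of piperidin-1-yl on a saturated chain carbon, three bonds along the chain from an oxygen on an aromatic ring; it makes a 1.1-fold higher number from compound 2 to compound 1 (0.03 log units; within the scatter). The change from compound 2 to compound 3 is 2,4,6-trimethylphenyl in place of 2-chloro-6-methylphenyl on an amide-type nitrogen; it makes a 1.3-fold lower number from compound 2 to compound 3 (0.13 log units; within the scatter). Compound 3 carries the lowest of the three numbers, but both its neighbours lie within the scatter of it, so no order among the three can be read.

Compound 4 `COc1cc2c(Nc3nc4ccc(C(=O)Nc5c(C)cc(C)cc5C)cc4s3)ncnc2cc1OCCCN1CCCC1` has not yet been measured in this assay. It differs from compound 3 by pyrrolidin-1-yl in place of piperidin-1-yl on a saturated chain carbon, three bonds along the chain from an oxygen on an aromatic ring. This is the same change that was made from compound 2 to compound 1, at the same place, and the two cores differ only by 2,4,6-trimethylphenyl in place of 2-chloro-6-methylphenyl on an amide-type nitrogen. The expected step for the change from compound 3 to compound 4 is a 1.1-fold higher number from compound 3 to compound 4 (0.03 log units; within the scatter), because the earlier instance of the same change gave a 1.1-fold higher number from compound 2 to compound 1 (0.03 log units; within the scatter) and left the number essentially unmoved. On that basis compound 4 is expected to give about 10000 nM in this assay, with a range estimated from 6000 nM to 17000 nM.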

Compound 4, half-maximal inhibitory concentration: 4300 nM
Beside the measured number, compound 4's estimate is 2.3-fold (0.37 log units) above it, outside the stated range (below it).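

In this assay, pyrrolidin-1-yl in place of piperidin-1-yl on the core of compound 3 gives a 2.2-fold lower number from compound 3 to compound 4 (0.34 log units; beyond the scatter), and 2,4,6-trimethylphenyl in place of 2-chloro-6-methylphenyl, with pyrrolidin-1-yl already present, gives a 3.1-fold lower number from compound 1 to compound 4 (0.49 log units; beyond the scatter). Among the compounds shown here, although only the step on the core of compound 3 lies beyond the scatter, the ring change cannot be said to behave differently on the two cores: the same change on two cores in this assay, a 1.1-fold higher number (0.03 log units; within the scatter) from compound 2 to compound 1 and a 2.2-fold lower number (0.34 log units; beyond the scatter) from compound 3 to compound 4, 2.3-fold (0.36 log units) apart, within the scatter of two such steps. The aryl change reads the same way, and these two comparisons rest on the same four compounds, so they show no firm dependence on the core but do not establish that either change carries over unaltered: the same change on two cores in this assay, a 1.3-fold lower number (0.13 log units; within the scatter) from compound 2 to compound 3 and a 3.1-fold lower number (0.49 log units; beyond the scatter) from compound 1 to compound 4, 2.3-fold (0.36 log units) apart, within the scatter of two such steps.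

On these data alone, it remains open whether the step seen with pyrrolidin-1-yl would recur on a third core, such as one with an unsubstituted phenyl on the amide-type nitrogen. Also open, as far as these compounds go, is how a morpholine or an open-chain dimethylamine in place of the ring at the end of the 3-(pyrrolidin-1-yl)propyl chain would read in this assay, and how a longer chain would read there.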